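Compound 4: a new group on the chain carbon

The source may hold more compounds than are shown below. What is called first, only, known or untested is meant among the compounds shown, and "the series" means these compounds.

Measured compounds in an ADME assay on A549 cells (Homo sapiens) for cytotoxicity, read by resazurin assay, with a stated time of 48 h; on this read-out higher numbers stand for lower toxicity in this test and lower numbers for higher toxicity in this test:
Compound 1 `CCNc1ccc(NC(=O)c2cc(Cl)ccc2O)c(Cl)c1` gives 30200 nM.
Compound 2 `O=C(Nc1ccc(NCC2CC2)cc1Cl)c1cc(Cl)ccc1O` gives 14400 nM.
Compound 3 `O=C(Nc1ccc(NCc2cc(Cl)cc(Cl)c2)cc1Cl)c1cc(Cl)ccc1O` gives 13300 nM.

Compound 3 gives the lowest of the three numbers in this assay, but its gap to compound 2 lies within the scatter, so the two cannot be ordered; only compound 1 stands clearly apart, with a higher number. Compound 4 `CC(C)(C)OC(=O)NCCNc1ccc(NC(=O)c2cc(Cl)ccc2O)c(Cl)c1` has not yet been measured. Its difference from compound 3 is ((tert-butoxycarbonyl)amino)methyl in place of 3,5-dichlorophenyl on a saturated chain carbon bound to a nitrogen on an aromatic ring.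

Within the data shown here, two measured steps concern the same place. The step of a 2.3-fold lower number from compound 1 to compound 3 (0.36 log units; beyond the scatter) shows that enlarging the group on that chain carbon from methyl to 3,5-dichlorophenyl lowered the number modestly, and the step of a 1.1-fold lower number from compound 2 to compound 3 (0.03 log units; within the scatter) shows no change beyond the scatter between cyclopropyl and 3,5-dichlorophenyl there. Among the measured compounds shown here, no measured step involves a group like ((tert-butoxycarbonyl)amino)methyl, so the direction of the new step rests on the fact that the smallest group, methyl in compound 1, gave the highest number. Compound 4 is therefore expected to return part of the way toward compound 1, with a modest rise estimated as a 1.5-fold higher number from compound 3 to compound 4 (0.18 log units; within the scatter). The estimate for compound 4 in this assay is 20000 nM, expected to fall between 8000 nM and 50000 nM.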

Compound 4, half-maximal cytotoxic concentration: 25000 nM
Estimate against measurement, compound 4: 1.3-fold (0.10 log units) below; the range from low to high includes it.
By their numbers in this assay, from the lowest: compounds 3, 2, 4 and 1 (each within the scatter of the next, the first and the last beyond it).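

In this assay, among these compounds, the ((tert-butoxycarbonyl)amino)methyl group, the first group at this chain carbon to carry nitrogen and oxygen and to have no ring, gave a number within the scatter of every earlier compound: a 1.9-fold higher number from compound 3 to compound 4 (0.27 log units; within the scatter), a 1.7-fold higher number from compound 2 to compound 4 (0.24 log units; within the scatter) and a 1.2-fold lower number from compound 1 to compound 4 (0.08 log units; within the scatter). Among the compounds shown here, compound 1 and compound 3 remain the only pair here that lies beyond the scatter, and compound 4 lies within the scatter of both, so this result neither supports nor weakens the earlier link between the smallest group and the highest number. No measurement shown here offers an explanation for this result.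

As far as these compounds go, it remains open whether the free amine, with the tert-butoxycarbonyl group gone from the chain, or a carboxylic acid at the end of the chain would give a number beyond the scatter of compound 4. The compounds shown also leave open whether a longer chain ending in the same (tert-butoxycarbonyl)amino group would separate from compound 1 or compound 3 in this assay.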